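The source may hold more compounds than are shown below. What is called first, only, known or untested is meant among the compounds shown, and "the series" means these compounds.

Of the compounds shown here, two have been measured in a functional assay on SNO cells (Homo sapiens) for cytotoxicity, read by XTT assay, with a stated time of 24 h; on this read-out higher numbers stand for weaker inhibition and lower numbers for stronger inhibition. Compound 1, with structure `CCOc1cc(C)c(Cl)c2c1C(=O)C=CC2=O`, gives 44200 nM. Compound 2, with structure `CC(=O)Oc1cc(OC(C)=O)c2c(OC(C)=O)cc(C)c(Cl)c2c1OC(C)=O`, gives 56900 nM. Of the two numbers, compound 2 has the higher one, but the gap to compound 1 lies within the usual scatter of repeated measurements, so on these data the two compounds cannot be told apart.

Compound 3, with structure `CC(=O)Oc1cc(OC(C)=O)c2c(OC(C)=O)cc(C)cc2c1OC(C)=O`, has not yet been measured. It differs from compound 2 in one place: hydrogen in place of chloro on an aromatic carbon. The change sits on an aromatic carbon of a six-membered aromatic ring of carbon only, ortho to a methyl group and para to an acetoxy group.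

Within the data shown here, no pair of measured compounds shows what such a change does here, so there is nothing to lean on beyond the two numbers already in hand. For that reason the expectation is a step in this assay from compound 2 to compound 3 of a 1.0-fold lower number from compound 2 to compound 3 (0.01 log units; within the scatter), that is, no change beyond the scatter in either direction. Compound 3 is therefore expected to give about 55000 nM, with a plausible range from 25000 nM to 120000 nM.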

Compound 3, half-maximal inhibitory concentration: 25000 nM
Compound 3: the middle estimate sits 2.2-fold (0.34 log units) above what was measured; the measured number falls inside the stated range.
By their numbers in this assay, from the lowest: compounds 3, 1 and 2 (each within the scatter of the next, the first and the last beyond it).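

In this assay, replacing the chloro group with hydrogen on the aromatic carbon, ortho to a methyl group and para to an acetoxy group, gives a 2.3-fold lower number from compound 2 to compound 3 (0.36 log units; beyond the scatter) in the direction of stronger inhibition. Among these compounds, this is the first measured change at this position, and it shows that the chloro group is not required for cytotoxicity on these cells: the compound without it is modestly stronger, and the step is small but clears the usual scatter. Nothing available explains why the number moves.

Only chloro and hydrogen are shown at this position, so it remains open whether a bromo group, a methoxy group or an amine would move the number further, or in the opposite direction. On these data alone, it is also open whether the same swap would have a similar effect on the core of compound 1, which differs from compound 2 in more than one place and so cannot be compared with it directly.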